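Swapping a butyl chain for a 2-methylphenyl on a thiourea

The source may report more compounds than this note shows. Statements on the series, on what has been measured and on what is new or still open speak of the compounds shown alone.

Compound 1 `CCCCNC(=S)N1CC(C)C(c2ccccc2)=N1` carries a butyl chain on the thiourea nitrogen of a shared core. In an ADME assay on KB cells (Homo sapiens) for cytotoxicity, read by MTT assay, with a stated time of 44 h (a lower number here means a stronger inhibitor, a higher number a weaker inhibitor), compound 1 gives only a limit, > 100000 nM. Compound 2 `CC1CN(C(=S)NC2CCCC2)N=C1c1ccccc1` likewise reaches only a limit in this assay, > 100000 nM. Compound 3 `CC1CN(C(=S)NC2CCCCCCC2)N=C1c1ccccc1` also sits at a limit, > 100000 nM. The step that the two limits leave unreadable from compound 1 to compound 2 therefore cannot be read, and all three values share (the limit of > 100000 nM in this assay, at which 3 of the 3 values shown sit). Compound 4 `Cc1ccccc1NC(=S)N1CC(C)C(c2ccccc2)=N1` differs from compound 1 by 2-methylphenyl in place of butyl on an amide-type nitrogen. Every measured step sits at a limit, and none shows how an aromatic group at this nitrogen behaves. The expectation is that compound 4 also shows no measurable cytotoxicity, a step of a number no higher from compound 1 to compound 4 (the limit leaves the size open) of no readable size. Compound 4 is estimated at 100000 nM, between 50000 nM and 300000 nM.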

Compound 4, half-maximal inhibitory concentration: > 100000 nM
Compound 4: a limit, no number; the forecaster's own chance of this, stated with the estimate: 80%; the middle value sits exactly at the limit.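

For the compounds shown here, no step from compound 1 or compound 2 to compound 4 can be read, since all of them stop at one limit: the limit of > 100000 nM in this assay, at which 4 of the 4 values shown sit.
From the compounds shown here alone, whether any group on this nitrogen gives a measurable value in this assay stays open.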